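Ethoxycarbonyl Gives Way to 3,4-Dichlorophenyl

The source may hold more compounds than are shown below. What is called first, only, known or untested is meant among the compounds shown, and "the series" means these compounds.

Measured so far:
compound 1, `O=C(CCCCC1CCSS1)NCc1cn(CCCOc2ccc3cc(-c4ccccc4)c(=O)oc3c2)nn1`, 27.2%
compound 2, `CCOC(=O)c1cc2ccc(OCCCCCn3cc(CNC(=O)CCCCC4CCSS4)nn3)cc2oc1=O`, 39.5%

In a functional assay on PC-12 cells (Rattus norvegicus) for cytotoxicity, read by MTT assay, with stated times of 3 h and 2 h, tested at 20 uM (a higher number here means a stronger effect of the compound at the concentration tested, a lower number a weaker effect), compound 2 gives 39.5%, the higher of the two numbers; compound 1 gives 27.2%, a gap beyond the usual scatter. Compound 3, `O=C(CCCCC1CCSS1)NCc1cn(CCCCCOc2ccc3cc(-c4ccc(Cl)c(Cl)c4)c(=O)oc3c2)nn1`, has not yet been measured. It differs from compound 2 in one place: 3,4-dichlorophenyl in place of ethoxycarbonyl on an aromatic carbon. Among the measured compounds shown here, no single-change step between measured compounds is available, so the size of this step is an expectation only. Compound 3 is expected to give 32% in this assay, within 18% to 48%. A small downward step a number 7.5 percentage points lower from compound 2 to compound 3 (within the scatter) is expected, not clearly beyond the scatter.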

Compound 3, a percentage reported as activity, at one concentration (the size of the read-out at that concentration, not a potency): 65.5%
For compound 3 the middle estimate is 33.5 percentage points below the measured one; measured number above the stated range.
By their numbers in this assay, from the lowest: compound 1; then compound 2; then compound 3.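

In this assay putting 3,4-dichlorophenyl in place of ethoxycarbonyl on this aromatic carbon gives a number 26 percentage points higher from compound 2 to compound 3 (beyond the scatter) for the step. This shows that the group held at this position of the shared core can move the read-out by more than repeat measurements would. Nothing available explains why this swap has that effect. Going by these compounds, whether the step comes from the aromatic ring itself or from its two chlorines stays open. How a carboxylic acid or an amine on this same carbon would compare is also unknown.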